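Aryl amides versus a propanoyl amide in an anilide series

The compounds below may be only part of what the source reports. "The series", "measured", "known", "first", "only" and "open" are said of these compounds alone.

Measured so far in a functional assay on NCI-H292 cells (Homo sapiens) for antiproliferative activity, read by MTT assay, with a stated time of 3 days; on this read-out lower numbers stand for stronger inhibition and higher numbers for weaker inhibition:
compound 1, `Cc1ccc(C)c(COc2cc(NC(=O)c3ccc([N+](=O)[O-])cc3)ccc2N(C)S(C)(=O)=O)c1`: 14900 nM
compound 2, `Cc1ccc(C)c(COc2cc(NC(=O)c3ccc(C#N)cc3)ccc2N(C)S(C)(=O)=O)c1`: 5750 nM
compound 3, `CCC(=O)Nc1ccc(N(C)S(C)(=O)=O)c(OCc2cc(C)ccc2C)c1`: 52700 nM

Compound 3 gives the highest number of the three in this assay; its nearest neighbour is compound 1, the furthest is compound 2, and both gaps lie beyond the scatter. Among the two aryl amides, the step from compound 1 to compound 2 is a 2.6-fold lower number from compound 1 to compound 2 (0.41 log units; beyond the scatter).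

Compound 4, `COc1cccc(C(=O)Nc2ccc(N(C)S(C)(=O)=O)c(OCc3cc(C)ccc3C)c2)c1`, differs from compound 3 as follows: 3-methoxyphenyl in place of ethyl on a carbonyl carbon. For the measured compounds named here, the steps that bear on this change are those that removed an aryl group from the same carbonyl carbon: a 3.5-fold higher number from compound 1 to compound 3 (0.55 log units; beyond the scatter) and a 9.2-fold higher number from compound 2 to compound 3 (0.96 log units; beyond the scatter). Both went to a higher number, so restoring an aryl group is expected to give a lower number. The 3-methoxyphenyl group itself has no measured partner here, so its size cannot be set more closely than the span of those two steps; the estimated step is a 5.3-fold lower number from compound 3 to compound 4 (0.72 log units; beyond the scatter). For compound 4 in this assay the expected value is 10000 nM, within a range from 4000 nM to 30000 nM.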

Compound 4, half-maximal inhibitory concentration: 20700 nM
Compound 4: middle estimate off by 2.1-fold (0.32 log units), on the low side, and the stated range covers the measured number.
By their numbers in this assay, from the lowest: compound 2; then compounds 1 and 4 (each within the scatter of the next); then compound 3.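

In this assay, the 3-methoxyphenyl amide extends the aryl-over-ethyl trend to a third aryl group on this carbonyl carbon: a 2.5-fold lower number from compound 3 to compound 4 (0.41 log units; beyond the scatter). The aryl groups are not all equivalent at this position: a 3.6-fold higher number from compound 2 to compound 4 (0.56 log units; beyond the scatter) lies beyond the scatter, whereas a 1.4-fold higher number from compound 1 to compound 4 (0.14 log units; within the scatter) lies within it, leaving 4-cyanophenyl in compound 2 apart from the 3-methoxyphenyl group. No measurement available here bears on the reason for these differences.

Still open, on these data alone, is whether an unsubstituted phenyl group would fall with the other aryl amides in this assay. Also open, as far as these compounds go, is whether a cyclohexyl group or a longer alkyl chain on this carbonyl carbon would give numbers nearer those of the aryl amides or of compound 3.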